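A Ring Closes on the Amine of Compound 2

A few compounds are considered here, and "the series" means these few. Any claim that something is new, unique, unknown or untested is made for them only; others in the source may bear on it.

Among the measured compounds shown here, compound 2 `CCNc1ccc(C(=O)N2CCCCc3cc(Cl)ccc32)c(Cl)c1` gives the lowest of the two numbers known so far in an assay on HeLa cells for binding affinity to Vasopressin V2 receptor (Homo sapiens); on this read-out higher numbers stand for weaker inhibition and lower numbers for stronger inhibition: in this assay compound 2 gives 5 nM. Its nearest neighbour is compound 1 `CCN(CC)c1ccc(C(=O)N2CCCCc3ccccc32)c(Cl)c1`, which in this assay gives 19 nM, a gap that lies beyond the usual scatter. For the measured compounds named here, the two measured compounds differ in more than one place, so no single-point step between them has been worked out; what compound 1 shows can only be set beside compound 2 as a pair of values.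

Compound 3 `O=C(c1ccc(N2CCCC2)cc1Cl)N1CCCCc2cc(Cl)ccc21` has not yet been measured in this assay. It differs from compound 2 in one place: pyrrolidin-1-yl in place of ethylamino on an aromatic carbon. Going by the values given here, with no measured pair showing this change, the expectation rests on the two values at hand, and the step is expected to be small, within or close to the scatter, leaning if anything toward a weaker number. The expected step is a 1.6-fold higher number from compound 2 to compound 3 (0.20 log units; within the scatter). Compound 3 is estimated to give 8 nM in this assay, within a range from 3 nM to 25 nM.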

Compound 3, half-maximal inhibitory concentration: 16 nM
Estimate against measurement, compound 3: 2.0-fold (0.30 log units) below; low and high end bracket the measured number.
By their numbers in this assay, from the lowest: compound 2; then compounds 3 and 1 (each within the scatter of the next).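

Among the compounds shown here, replacing the ethylamino group with pyrrolidin-1-yl on this aromatic carbon, para to a large group and meta to a chloro group, gives the first single-point step in this assay, which is a 3.2-fold higher number from compound 2 to compound 3 (0.51 log units; beyond the scatter). The earlier compounds shown here could only be set side by side as a pair of values, whereas this step lies beyond the usual scatter and shows that the number at this position responds to the change, though only modestly. The exchange adds a five-membered non-aromatic ring and leaves no hydrogen-bond donor in the group, and this one step cannot separate these two differences. Nothing on hand speaks to why the number moves.

Still open, from the compounds shown here alone, is how a larger ring such as piperidin-1-yl, or a ring with an oxygen atom such as morpholin-4-yl, would read at this position, and whether an open-chain dimethylamino group would match the pyrrolidin-1-yl ring or the ethylamino group. The chloro group that the core of compound 2 carries and the core of compound 1 lacks also has no single-point partner, so its part in these values remains unread.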